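Changing the aryl group on the ring nitrogen

The source may hold more compounds than are shown below. What is called first, only, known or untested is meant among the compounds shown, and "the series" means these compounds.

Compound 1 `O=C(NCCCCc1ccccc1)c1cccc(C2SCC(=O)N2c2cnccn2)c1` and compound 2 `C#Cc1cccc(N2C(=O)CSC2c2cccc(C(=O)NCCCCc3ccccc3)c2)c1` share one core and differ only in the group on the amide-type nitrogen in a ring. In a functional assay on HOS-TE85 cells (Homo sapiens) for inhibition, read by CCK-8 assay, with a stated time of 72 h (a lower number here means a stronger inhibitor, a higher number a weaker inhibitor), compound 1 gives > 1000 nM, which is a limit of the assay and not a number. Going by the values given here, compound 2 gives 149 nM, the only true number so far, and it is the stronger inhibitor of the two. Among the compounds with values here, the one measured step is an at least 6.7-fold lower number from compound 1 to compound 2 (0.82 log units; beyond the scatter), and it came with 3-ethynylphenyl in place of pyrazin-2-yl.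

Compound 3 `COc1cccc(OC)c1N1C(=O)CSC1c1cccc(C(=O)NCCCCc2ccccc2)c1` changes the same place, with 2,6-dimethoxyphenyl in place of 3-ethynylphenyl (2,6-dimethoxyphenyl in place of 3-ethynylphenyl on an amide-type nitrogen in a ring). Within the data shown here, no measured compound carries this group, so the direction rests on thin ground. Among the measured compounds shown here, since the only change at this place gave an at least 6.7-fold lower number from compound 1 to compound 2 (0.82 log units; beyond the scatter), a real step is expected here too, with a higher number in this assay as the likelier outcome. The expected step is a 2.7-fold higher number from compound 2 to compound 3 (0.43 log units; beyond the scatter), and this size is an estimate only. For compound 3 the estimated value is 400 nM, with an expected range of 130 nM to 1300 nM.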

Compound 3, half-maximal inhibitory concentration: > 1000 nM
Compound 3: a limit, no number (the forecaster's own chance of this, stated with the estimate: 25%); at least 2.5-fold (0.39 log units) between middle value and limit.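

Compound 2 now stands apart from two different replacements on the amide-type nitrogen in a ring: in this assay, 2,6-dimethoxyphenyl in place of 3-ethynylphenyl gives an at least 6.7-fold higher number from compound 2 to compound 3 (0.82 log units; beyond the scatter). Compound 3 keeps a six-membered aromatic ring of carbon only, as compound 2 does, so such a ring alone does not carry the compound to a true number in this assay, and among the three groups shown only 3-ethynylphenyl reaches one. The values of compound 1 and compound 3 are both limits of the assay and not numbers, and the step between them cannot be read because the two compounds share one ceiling: the limit of > 1000 nM in this assay, at which 2 of the 3 values shown sit.

Going by these compounds, how far compound 1 and compound 3 lie beyond that limit remains open, so the full size of both steps from compound 2 is unknown, and the two replacements cannot be ranked against each other. Also open, on these data alone, is what the ethynyl group itself contributes, a question that an unsubstituted phenyl, a phenyl with a single methoxy group, or a phenyl bearing an amine or a carboxylic acid at this position would address.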